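Swapping a Triazolyl Ring for Methylsulfanyl: an Expectation

The source may report more compounds than this note shows. Statements on the series, on what has been measured and on what is new or still open speak of the compounds shown alone.

Compound 1 `CNc1nc(NC2(C#N)CCCCC2)nc(-n2cncn2)n1` was tested in an in vitro assay on Sf21 cells for inhibition of high affinity 3',5'-cyclic-AMP phosphodiesterase 7A (Homo sapiens); a higher number here means a weaker inhibitor, a lower number a stronger inhibitor. In this assay compound 1 gives > 5000 nM, which is a limit of the assay and not a number. Compound 2 `CNc1nc(NC2(C#N)CCCCC2)nc(N2CCCC2)n1` shares the core of compound 1 and differs by pyrrolidin-1-yl in place of 1H-1,2,4-triazol-1-yl on an aromatic carbon. In this assay compound 2 gives > 5000 nM, again a limit of the assay. The step that the two limits leave unreadable from compound 1 to compound 2 cannot be read because of the limit of > 5000 nM in this assay, at which 2 of the 2 values shown sit. Compound 1 thus stands at the limit, with no measured neighbour that gives a number.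

Compound 3 `CNc1nc(NC2(C#N)CCCCC2)nc(SC)n1` has not yet been measured. It differs from compound 1 as follows: methylsulfanyl in place of 1H-1,2,4-triazol-1-yl on an aromatic carbon. For the measured compounds named here, only the step that the two limits leave unreadable from compound 1 to compound 2 replaces the same group, and it was unreadable, so no measured step shows what this change does in this assay. Without such a guide, compound 3 is expected to remain weak, most likely again at the limit, with a step that the limit leaves unreadable from compound 1 to compound 3 that is estimated to lie within the scatter. Compound 3 is therefore estimated at 8000 nM, ranging from 2000 nM to 50000 nM.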

Compound 3, half-maximal inhibitory concentration: 46 nM
The estimate for compound 3 lay 170-fold (2.24 log units) above the measured number, outside the stated range (below it).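

The position between two ring nitrogen atoms, opposite the ring nitrogen, turns out not to be indifferent to what it carries, which compound 1 and compound 2 could not show. In this assay, methylsulfanyl in place of 1H-1,2,4-triazol-1-yl gives an at least 100-fold lower number from compound 1 to compound 3 (2.03 log units; beyond the scatter), and methylsulfanyl in place of pyrrolidin-1-yl gives an at least 100-fold lower number from compound 2 to compound 3 (2.03 log units; beyond the scatter), so the same large change appears against both ring-bearing groups, and methylsulfanyl, the only group shown here with no ring, is also the only one with a measured number. The step between the two ring-bearing groups still cannot be read, and the two new steps give only the least size of the change, because the values of compound 1 and compound 2 are limits and not numbers: the limit of > 5000 nM in this assay, at which 2 of the 3 values shown sit.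

The compounds shown leave open whether this gain belongs to methylsulfanyl itself or would also appear at this place with methoxy, ethylsulfanyl or a longer sulfur-bearing chain. They also leave open whether methylsulfanyl keeps this effect when the methylamino group is replaced by an ethylamino group.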